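A few compounds are considered here, and "the series" means these few. Any claim that something is new, unique, unknown or untested is made for them only; others in the source may bear on it.

Of the compounds shown here, three have so far been tested in a functional assay on MCF7 cells (Homo sapiens) for cytotoxicity, read by sulforhodamine B assay, with a stated time of 48 h; on this read-out higher numbers stand for weaker inhibition of growth and lower numbers for stronger inhibition of growth. Compound 1, with the structure `O=C1C(=O)N(CN2CCN(c3ccnc4cc(C(F)(F)F)ccc34)CC2)c2cccc(Cl)c21`, gives 16900 nM in this assay. Compound 2, with the structure `O=C1C(=O)N(CN2CCN(c3ccnc4cc(C(F)(F)F)ccc34)CC2)c2cccc(Br)c21`, differs from it in one place: bromo in place of chloro on an aromatic carbon. In this assay compound 2 gives 66800 nM, and the step of a 4.0-fold higher number from compound 1 to compound 2 (0.60 log units; beyond the scatter) therefore goes toward weaker growth inhibition. Compound 3, with the structure `NC(=S)N/N=C1/C(=O)N(CN2CCN(c3ccnc4cc(Cl)ccc34)CC2)c2cccc(Cl)c21`, is built on a different core; the difference between its core and the core of compound 1 is not broken down here. In this assay compound 3 gives 57500 nM, which is close to the number for compound 2 and clearly higher than the number for compound 1.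

Compound 4, with the structure `NC(=S)N/N=C1/C(=O)N(CN2CCN(c3ccnc4cc(Cl)ccc34)CC2)c2cccc(Br)c21`, has not yet been measured. It differs from compound 3 in one place: bromo in place of chloro on an aromatic carbon. The place of this change is described in exactly the same words as for the pair compound 1 and compound 2, so it is the same change, made on a different core. Within the data shown here, only one earlier example of this change exists, and there it weakened growth inhibition. On that basis the same direction is expected here, estimated as a 2.6-fold higher number from compound 3 to compound 4 (0.42 log units; beyond the scatter). Because compound 3 already gives 57500 nM, such a step would place compound 4 at the weak end of what has been seen. The estimate for compound 4 in this assay is 150000 nM, within 50000 nM to 400000 nM.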

Compound 4, concentration for 50% growth inhibition: 46600 nM
Compound 4: middle estimate off by 3.2-fold (0.51 log units), on the high side; the whole stated range lies above it.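

In this assay, the step on the core of compound 3 reads a 1.2-fold lower number from compound 3 to compound 4 (0.09 log units; within the scatter), and set beside the earlier step on the core of compound 1, the two do not agree: the same change on two cores in this assay, a 4.0-fold higher number (0.60 log units; beyond the scatter) from compound 1 to compound 2 and a 1.2-fold lower number (0.09 log units; within the scatter) from compound 3 to compound 4, 4.9-fold (0.69 log units) apart, beyond the scatter of two such steps

So the same exchange of chloro for bromo at the same place weakened growth inhibition on one core and made no change beyond the scatter on the other, which means that the earlier step cannot simply be carried over as a fixed amount. What this does not show is which part of the cores is responsible, since the core of compound 1 and the core of compound 3 differ in more than one place, and two pairs are too few to support a general rule for the series.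

The compounds shown leave open how a plain hydrogen, a fluoro or a methoxy group at this same place would read on either core, and whether a more distant change, such as an amine or a carboxylic acid, would behave alike on both. They also leave open how the chloro and bromo pair would read on a core that carries only one of the differences, for example trifluoromethyl in place of the second chloro on the core of compound 3.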